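The source may hold more compounds than are shown below. What is called first, only, known or untested is meant among the compounds shown, and "the series" means these compounds.

Measured so far:
Compound 1 `O=C(CN1CCC(Cc2ccccc2)CC1)Nc1ccc(C(=O)/C=C/c2cn(Cc3ccc(Br)cc3)nn2)cc1`; in a functional assay on MCF7 cells (Homo sapiens) for inhibition, read by MTT assay (on this read-out higher numbers stand for weaker inhibition and lower numbers for stronger inhibition), compound 1 gives 54500 nM.
Compound 2 `O=C(CN1CCN(c2ccccc2F)CC1)Nc1ccc(C(=O)/C=C/c2cn(Cc3ccc(Br)cc3)nn2)cc1`; in this assay compound 2 gives 11300 nM.

Compound 2 holds the lower of the two numbers; compound 1 sits well above it, a gap beyond the usual scatter. Compound 3 `CC(C)(C)OC(=O)N1CCN(CC(=O)Nc2ccc(C(=O)/C=C/c3cn(Cc4ccc(Br)cc4)nn3)cc2)CC1` is not yet measured. It differs from compound 2 in one place: tert-butoxycarbonyl in place of 2-fluorophenyl on an amine nitrogen in a ring. For the measured compounds named here, no measured pair shows this change, so the expectation rests on little. A modest step toward weaker inhibition in this assay is expected, roughly a 2.2-fold higher number from compound 2 to compound 3 (0.34 log units; beyond the scatter). For compound 3 the estimated value is 25000 nM, with a range from 8000 nM to 80000 nM.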

Compound 3, half-maximal inhibitory concentration: 31000 nM
Beside the measured number, compound 3's estimate is 1.2-fold (0.09 log units) below it, within the range that was stated.
By their numbers in this assay, from the lowest: compound 2; then compounds 3 and 1 (each within the scatter of the next).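

Swapping 2-fluorophenyl for tert-butoxycarbonyl on the amine nitrogen in the ring gives a 2.7-fold higher number from compound 2 to compound 3 (0.44 log units; beyond the scatter) in this assay, a modest move toward weaker inhibition. This nitrogen therefore carries a group with no ring and with hydrogen-bond acceptors, and inhibition still gives a measurable number. Nothing available explains the step.

This single change removes the aromatic ring and adds the acceptors together, leaving their contributions unseparated. A free amine, an acetyl group or a benzyl group on this nitrogen remains an open comparison.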